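The source may hold more compounds than are shown below. What is called first, only, known or untested is meant among the compounds shown, and "the series" means these compounds.

Compound 2 `COc1ccc(NC(=O)COc2cc(C)nc3ccc(OC)cc23)cc1` stands at the upper end of the numbers gathered so far. In an ADME assay on HepG2 cells (Homo sapiens) for cytotoxicity, read by trypan blue exclusion, with a stated time of 48 h, in the presence of a further agent that is not named here (a higher number here means that more compound is tolerated, a lower number that less compound is tolerated), compound 2 gives > 142000 nM, which is not a number but a limit of the assay (the limit of > 142000 nM in this assay, at which 1 of the 2 values shown sits). Among the compounds with values here, its one measured neighbour is compound 1 `COc1cccc(NC(=O)COc2cc(C)nc3ccc(OC)cc23)c1`, which carries the same core but a 3-methoxyphenyl instead of a 4-methoxyphenyl on the amide-type nitrogen. In this assay compound 1 gives 24700 nM. Within the data shown here, the single measured step of an at least 5.7-fold higher number from compound 1 to compound 2 (0.75 log units; beyond the scatter) shows that shifting the methoxy group on that phenyl lets the cells tolerate a great deal more compound. Compound 3 `COc1ccc2nc(C)cc(OCC(=O)Nc3ccc(OC)c(OC)c3)c2c1` takes compound 2 and adds a second methoxy group: methoxy in place of hydrogen on an aromatic carbon. Among the measured compounds shown here, compound 3 thus carries the methoxy arrangement of compound 2 together with the one that in compound 1 went with 24700 nM. For the measured compounds named here, with only that one step to lean on, the expectation is a modest fall rather than none, though likely not all the way back to the level of compound 1. The estimate for compound 3 is 90000 nM, with a range from 30000 nM to 200000 nM. The expected step is an at least 1.5-fold lower number from compound 2 to compound 3 (0.19 log units; that floor lies within the scatter), and the result may well again be reported only as a limit.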

Compound 3, half-maximal cytotoxic concentration: > 131000 nM
Compound 3: no number, only a limit; the forecaster's own chance of this, stated with the estimate: 45%; middle value at least 1.4-fold (0.16 log units) from the limit.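

In this assay compound 3 gives > 131000 nM, which is a limit of the assay and not a number. Its two methoxy groups on the phenyl ring give an at least 5.3-fold higher number from compound 1 to compound 3 (0.72 log units; beyond the scatter), so the methoxy placement that earlier went with the lower tolerated concentration does not bring that lower level with it when the methoxy group of the 4-methoxyphenyl is also present. From the compounds shown here alone, the step between the 4-methoxyphenyl compound and its dimethoxy partner cannot be read, since both values are limits, so the added methoxy group, ortho to a methoxy group and meta to a large group, shows no drop into the measurable range, but its true size of effect stays unknown.

Going by these compounds, what remains open is whether the added methoxy group changes tolerance at all, since neither of the two compounds has a measured number in this assay. On these data alone, it is also open whether this place on the ring would tolerate something quite different from a methoxy group, such as an amine, a carboxylic acid or a longer alkoxy chain.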